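Trifluoromethyl in place of chloro on compound 1

The source may hold more compounds than are shown below. What is called first, only, known or untested is meant among the compounds shown, and "the series" means these compounds.

For the measured compounds named here, in a toxicity assay on Vero C1008 cells (Chlorocebus sabaeus) for cytotoxicity, read by MTT assay, with a stated time of 48 h (on this read-out higher numbers stand for lower toxicity in this test and lower numbers for higher toxicity in this test), compound 1 `O=C(Nc1cccc(Cl)c1)c1cc(Cl)ccc1O` gives 2460 nM and compound 2 `O=C(Nc1ccc(F)c(Cl)c1)c1cc(Cl)ccc1O` gives 2440 nM within the scatter of each other, so compound 1 stands level with the only other measured number. Compound 3 `O=C(Nc1cccc(C(F)(F)F)c1)c1cc(Cl)ccc1O` carries trifluoromethyl in place of chloro on an aromatic carbon. Going by the values given here, the one measured step (a 1.0-fold lower number from compound 1 to compound 2 (0.00 log units; within the scatter)) is a different change, fluoro in place of hydrogen on an aromatic carbon, and it stays within the scatter, so it offers only weak guidance. No shift beyond the scatter is expected in this assay, and the expected step is small (a 1.1-fold lower number from compound 1 to compound 3 (0.03 log units; within the scatter)). Compound 3 is estimated at 2300 nM (range 1000 nM to 5200 nM).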

Compound 3, half-maximal cytotoxic concentration in the Vero C1008 assay: 5950 nM
The estimate for compound 3 lay 2.6-fold (0.41 log units) below the measured number, outside the stated range (above it).
By their numbers in the Vero C1008 assay, from the lowest: compounds 2 and 1 (each within the scatter of the next); then compound 3.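

At this place, on an aromatic carbon meta to a large group, the change does move the read-out beyond the scatter, unlike the earlier fluoro step: in the Vero C1008 assay trifluoromethyl in place of chloro gives a 2.4-fold higher number from compound 1 to compound 3 (0.38 log units; beyond the scatter). In a physicochemical assay for solubility, read by HPLC (on this read-out lower numbers stand for lower solubility and higher numbers for higher solubility), the step is an at least 8.4-fold higher number from compound 1 to compound 3 (0.92 log units; beyond the scatter). In the physicochemical assay compound 3 gives 8.4 ug/mL. In the physicochemical assay compound 1 gives < 1 ug/mL, which is a limit of the assay, not a number: the limit of < 1 ug/mL in the physicochemical assay, at which 1 of the 2 values shown sits.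

A single pair cannot tell whether the two shifts travel together. Going by these compounds, how a nitrile or an amine at this place would move the half-maximal cytotoxic concentration or the solubility stays open.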